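Trifluoromethyl to Tert-Butyl: Expected Cytotoxicity of Compound 4

A few compounds are considered here, and "the series" means these few. Any claim that something is new, unique, unknown or untested is made for them only; others in the source may bear on it.

Compound 1 `Cc1cc(NC(=O)Nc2ccccc2C(F)(F)F)c2ccccc2n1`: in an ADME assay on BJ cells (Homo sapiens) for cytotoxicity, with a stated time of 72 h (a higher number here means that more compound is needed for the effect, a lower number that less compound is needed), compound 1 reaches only the assay limit, > 25000 nM.
Compound 2 `COc1ccc(NC(=O)Nc2cc(C)nc3ccccc23)cc1OC`: in this assay compound 2 likewise reaches only the assay limit, > 25000 nM.
Compound 3 `Cc1cc(NC(=O)Nc2cccc(OC(F)(F)F)c2)c2ccccc2n1`: in this assay compound 3 gives 25000 nM.

All three measured ureas share one core, and none of them shows a measurable toxic effect on these cells within the tested range. Compound 1 stands at the limit of > 25000 nM in this assay, at which 2 of the 3 values shown sit, so for it only a limit is known and no number. Compound 3 sits at the same concentration as a measured value, and compound 2 sits at the limit as well. Among the measured compounds shown here, no two of these measured compounds differ in just one place, so no measured step is available to gauge how a single change moves the result.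

Compound 4 `Cc1cc(NC(=O)Nc2ccccc2C(C)(C)C)c2ccccc2n1` differs from compound 1 in one place: tert-butyl in place of trifluoromethyl on an aromatic carbon. Both groups are small, without rings, donors or acceptors, and the measured compounds give no sign that any change of this kind pulls the read-out away from the limit. The step from compound 1 to compound 4 in this assay is therefore expected to be none beyond the usual scatter, as a number no higher from compound 1 to compound 4 (the limit leaves the size open) expresses. Compound 4 is thus estimated at 25000 nM, within a range from 12000 nM to 60000 nM, with a good chance that the assay again reports only a limit.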

Compound 4, half-maximal effective concentration: 22000 nM
Compound 4: middle estimate off by 1.1-fold (0.06 log units), on the high side, within the range that was stated.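

With compound 4, this assay now has a step that changes one place only, tert-butyl in place of trifluoromethyl on an aromatic carbon, and that step is an at least 1.1-fold lower number from compound 1 to compound 4 (0.05 log units; that floor lies within the scatter) for this exchange. Compound 4 also gives a measured number, 22000 nM in this case, so this change at this position yields a value that can be read directly. On these data alone, the true size of the step remains unknown because compound 1 has only a limit and no number, so the printed step is a floor and not a measurement of the full change: (the limit of > 25000 nM in this assay, at which 2 of the 4 values shown sit).

The compounds shown leave open whether a group of a different kind at this same place, such as an amine, a carboxylic acid or a longer chain, would keep the read-out in this range. Among the compounds shown here, they also leave open whether exchanging trifluoromethyl for tert-butyl at another place on the ring would give a similarly small step, since this single pair is the only one-place comparison available.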